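Moving the chlorine on the anilino ring of compound 2

The compounds below may be only part of what the source reports. "The series", "measured", "known", "first", "only" and "open" are said of these compounds alone.

In a functional assay on PANC-1 cells (Homo sapiens) for antiproliferative activity, read by CCK-8 assay, with a stated time of 72 h (on this read-out lower numbers stand for stronger inhibition and higher numbers for weaker inhibition), compound 1 `Cc1cc(Nc2cc(N3CCN(C)CC3)nc(Nc3ccc([N+](=O)[O-])cc3)n2)n[nH]1` gives 442 nM. Compound 2 `Cc1cc(Nc2cc(N3CCN(C)CC3)nc(Nc3ccc(Cl)cc3)n2)n[nH]1` gives 455 nM, the higher of the two numbers, though the step of a 1.0-fold higher number from compound 1 to compound 2 (0.01 log units; within the scatter) lies within the scatter. Compound 3 `Cc1cc(Nc2cc(N3CCN(C)CC3)nc(Nc3cccc(Cl)c3)n2)n[nH]1` differs from compound 2 by 3-chlorophenyl in place of 4-chlorophenyl on a nitrogen on an aromatic ring. Within the data shown here, no measured step concerns the placement of the chlorine; the single step seen, nitro to chloro, stayed within the scatter, so nothing measured points to a change here. The expected step is a 1.0-fold lower number from compound 2 to compound 3 (0.00 log units; within the scatter), within the scatter. Compound 3 is estimated at 450 nM, with a range from 200 nM to 1000 nM.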

Compound 3, half-maximal inhibitory concentration: 351 nM
For compound 3 the middle estimate is 1.3-fold (0.11 log units) above the measured one, within the range that was stated.
By their numbers in this assay, from the lowest: compounds 3, 1 and 2 (each within the scatter of the next).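

In this assay, among these compounds, the step of a 1.3-fold lower number from compound 2 to compound 3 (0.11 log units; within the scatter) is the first measured one on the placement of the chlorine, and the step of a 1.3-fold lower number from compound 1 to compound 3 (0.10 log units; within the scatter) also stays within the scatter. Among these three compounds, neither the change of place nor the change from 4-nitrophenyl to 3-chlorophenyl gives a step beyond the scatter. No measurement shown bears on the reason for this result.
The compounds shown leave open whether an amine or a carboxylic acid in place of the chlorine would stay within the scatter. They also leave open whether the same holds with a longer chain on this ring.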